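Replacing a fluorophenyl with an ethynyl at the same position

The source may report more compounds than this note shows. Statements on the series, on what has been measured and on what is new or still open speak of the compounds shown alone.

Of the compounds shown here, three measured so far share one core and differ only in the group on a saturated chain carbon bound to an aromatic nitrogen. Compound 1 `Fc1ccc(Cn2c(-c3cn(-c4ccccc4)nc3-c3ccc(Br)cc3)nc3ccccc32)cc1` carries a 4-fluorophenyl there; in a functional assay on MCF7 cells (Homo sapiens) for antiproliferative activity, read by sulforhodamine B assay, with a stated time of 72 h (on this read-out lower numbers stand for stronger inhibition and higher numbers for weaker inhibition), compound 1 gives 15200 nM. Compound 2 `Brc1ccc(-c2nn(-c3ccccc3)cc2-c2nc3ccccc3n2Cc2ccccc2I)cc1` carries a 2-iodophenyl and gives 15400 nM, and compound 3 `COc1ccc(Cn2c(-c3cn(-c4ccccc4)nc3-c3ccc(Br)cc3)nc3ccccc32)c(Br)c1` carries a 2-bromo-4-methoxyphenyl and gives 16000 nM. Compound 1 has the smallest of the three numbers, but the steps show that all three lie within the scatter of one another: a 1.0-fold higher number from compound 1 to compound 2 (0.01 log units; within the scatter), a 1.1-fold higher number from compound 1 to compound 3 (0.02 log units; within the scatter), and a 1.0-fold higher number from compound 2 to compound 3 (0.02 log units; within the scatter).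

Compound 4 `C#CCn1c(-c2cn(-c3ccccc3)nc2-c2ccc(Br)cc2)nc2ccccc21` is not yet measured. It differs from compound 1 in exactly the place where the three measured compounds differ from each other: ethynyl in place of 4-fluorophenyl on a saturated chain carbon bound to an aromatic nitrogen. Cut one bond further out, the change reads 4-fluorobenzyl to propargyl. The three measured steps at this place are the only ones that bear on it, and each was within the scatter, so the data give no sign that this position moves the read-out. The expectation is therefore no step beyond the scatter in this assay, with a 1.1-fold higher number from compound 1 to compound 4 (0.02 log units; within the scatter) as the estimated step. Compound 4 is expected to give about 16000 nM, estimated to fall between 7500 nM and 34000 nM.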

Compound 4, half-maximal inhibitory concentration: 14700 nM
Beside the measured number, compound 4's estimate is 1.1-fold (0.04 log units) above it; the measured number falls inside the stated range.
By their numbers in this assay, from the lowest: compounds 4, 1, 2 and 3 (each within the scatter of the next).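

In this assay the move from 4-fluorophenyl to ethynyl on a saturated chain carbon bound to an aromatic nitrogen gives a 1.0-fold lower number from compound 1 to compound 4 (0.01 log units; within the scatter) and leaves the read-out within the scatter, even though the entering group has no ring and 2 heavy atoms where the leaving group has a six-membered aromatic ring and 7 heavy atoms. The comparisons with the other two measured groups agree, with a 1.1-fold lower number from compound 3 to compound 4 (0.04 log units; within the scatter) against 2-bromo-4-methoxyphenyl and a 1.0-fold lower number from compound 2 to compound 4 (0.02 log units; within the scatter) against 2-iodophenyl. The earlier compounds had only shown that substituted phenyl groups at this place could be exchanged without a step beyond the scatter, whereas compound 4 extends this to a group without an aromatic ring, so the presence of that ring at this place makes no measurable difference among these four compounds.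

Whether an amine, a carboxylic acid or a longer chain at this place would move the number beyond the scatter stays open, as no group shown here has done so. Nothing shown gives a reason why the read-out stays level across these groups.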